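A Ring-Nitrogen Substituent Change Tested on a Second Core

The compounds below may be only part of what the source reports. "The series", "measured", "known", "first", "only" and "open" are said of these compounds alone.

Compound 1 `CC(C)(C)CN1CCC(NCCSC(c2ccc(F)cc2)c2ccc(F)cc2)CC1` and compound 3 `O=C(c1ccccc1F)N1CCC(NCCSC(c2ccc(F)cc2)c2ccc(F)cc2)CC1` share a core and differ in one place: (2-fluorophenyl)carbonyl in place of neopentyl on an amine nitrogen in a ring. In an assay on membranes from Cortex for displacement of a labelled ligand from Sigma non-opioid intracellular receptor 1 (Cavia porcellus), read by scintillation counting, with a stated time of 120 min (on this read-out higher numbers stand for weaker inhibition and lower numbers for stronger inhibition), compound 1 gives 315 nM, while compound 3 gives 3.57 nM, so this change made an 88-fold lower number from compound 1 to compound 3 (1.95 log units; beyond the scatter). Compound 2 `CC(C)(C)CN1CCC(NCC[S+]([O-])C(c2ccc(F)cc2)c2ccc(F)cc2)CC1` gives 542 nM in this assay, a value within the scatter of compound 1; how the core of compound 2 differs from that of compound 1 is not broken down here. Compound 4 `O=C(c1ccccc1F)N1CCC(NCC[S+]([O-])C(c2ccc(F)cc2)c2ccc(F)cc2)CC1` has not yet been measured. It carries the same change on the core of compound 2: (2-fluorophenyl)carbonyl in place of neopentyl on an amine nitrogen in a ring. The place is the same in both pairs, word for word, so the two steps are the same change. The earlier step of an 88-fold lower number from compound 1 to compound 3 (1.95 log units; beyond the scatter) was large, and compound 2 at 542 nM lies close to compound 1, which gives a basis for expecting a step of similar size. The step expected in this assay is a 77-fold lower number from compound 2 to compound 4 (1.89 log units; beyond the scatter). The estimate for compound 4 in this assay is 7 nM, expected to fall between 2 nM and 25 nM.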

Compound 4, inhibition constant: 1310 nM
Beside the measured number, compound 4's estimate is 190-fold (2.27 log units) below it; measured number above the stated range.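

In this assay the change did not carry from one core to the other in the same way: the same change on two cores in this assay, an 88-fold lower number (1.95 log units; beyond the scatter) from compound 1 to compound 3 and a 2.4-fold higher number (0.38 log units; beyond the scatter) from compound 2 to compound 4, 210-fold (2.33 log units) apart, beyond the scatter of two such steps. On the core of compound 2, putting (2-fluorophenyl)carbonyl in place of neopentyl gave a 2.4-fold higher number from compound 2 to compound 4 (0.38 log units; beyond the scatter), a modest step in the opposite direction to the large one on the core of compound 1, even though compound 1 and compound 2 lie within the scatter of each other. This shows that, across these two pairs, the outcome of the change depended on the core and that a similar starting value was no guide to it, but it does not show which feature of the core is responsible or how the change would behave on any further core.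

On these data alone, it remains open whether an acetyl or a benzyl group on the amine nitrogen in the ring would also respond differently on the two cores. The same question stands for a longer alkyl chain in that place.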